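Notes on the step from compound 2 to compound 3

The source may report more compounds than this note shows. Statements on the series, on what has been measured and on what is new or still open speak of the compounds shown alone.

Measured compounds:
compound 1 `O=S(=O)(Nc1ccc2oc(-c3ccccc3)nc2c1)c1ccccc1F`: > 100000 nM in an assay on cells for inhibition of HSP60/HSP10 (Homo sapiens), with a stated time of 60 min; a higher number here means a weaker inhibitor, a lower number a stronger inhibitor
compound 2 `O=S(=O)(Nc1ccc2oc(-c3ccccc3)nc2c1)c1ccccc1O`: 85000 nM

In this assay compound 1 gives > 100000 nM, which is a limit of the assay and not a number. Compound 2 gives 85000 nM, the only number shown here. The step of an at least 1.1-fold lower number from compound 1 to compound 2 (0.07 log units; that floor lies within the scatter) rests on that limit of > 100000 nM in this assay, at which 1 of the 2 values shown sits, and lies within the scatter, so it carries no direction.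

Compound 3 `O=S(=O)(Nc1ccc2oc(-c3ccccc3)nc2c1)c1ccccc1C(F)(F)F` differs from compound 2 by trifluoromethyl in place of hydroxy on an aromatic carbon. Within the data shown here, the only measured step exchanges fluoro for hydroxy at this same aromatic carbon; it is small and bounded by a limit, so it gives no measured size for the present change. No step beyond the scatter is therefore expected in this assay, and the result may again be a limit.

Compound 3 is expected near 100000 nM, with a range from 40000 nM to 300000 nM. That estimate means a step of a 1.2-fold higher number from compound 2 to compound 3 (0.07 log units; within the scatter).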

Compound 3, half-maximal inhibitory concentration: > 100000 nM
Compound 3: a limit, no number; the forecaster's own chance of this, stated with the estimate: 55%; the middle value sits exactly at the limit.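

In this assay compound 3 gives > 100000 nM, which is a limit of the assay and not a number. The step of an at least 1.1-fold higher number from compound 2 to compound 3 (0.07 log units; that floor lies within the scatter) rests on that limit and carries no direction, so trifluoromethyl in place of hydroxy on this aromatic carbon shows no readable change, and the step from fluoro to trifluoromethyl cannot be read, with a limit at both ends. Hydroxy remains the only group at this position with a number, and the readings here now stand mostly at one limit: the limit of > 100000 nM in this assay, at which 2 of the 3 values shown sit.

From the compounds shown here alone, whether hydroxy differs at all from fluoro or trifluoromethyl at this position stays open. Also open, going by these compounds, is what an amine, a carboxylic acid or a methoxy group would give on this aromatic carbon in this assay.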